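A Chloro on the Benzyl Arm: Expected Cytotoxicity

This account rests on a few compounds, and the source may have more. Where it says the series, first, only, none or still open, it means among the compounds named here.

Compound 3 `O=[N+]([O-])c1cc(-c2nnn(Cc3ccccc3)n2)cc([N+](=O)[O-])c1` was tested in an ADME assay on CHO-K1 cells (Cricetulus griseus) for cytotoxicity, read by MTT assay, with a stated time of 24 h (a higher number here means a weaker inhibitor, a lower number a stronger inhibitor), where compound 3 gives 150000 nM. Compound 1 `O=[N+]([O-])c1cc(Sc2nnnn2C2CCCCC2)cc([N+](=O)[O-])c1` gives 153000 nM in this assay, a value within the scatter of that of compound 3, so the two cannot be told apart. Compound 2 `CCCCCCCCCCCCn1nnc(-c2cc([N+](=O)[O-])cc([N+](=O)[O-])c2)n1` gives only a limit in this assay, > 200000 nM (the limit of > 200000 nM in this assay, at which 1 of the 3 values shown sits). The untested compound 4 `O=[N+]([O-])c1cc(-c2nnn(Cc3ccc(Cl)cc3)n2)cc([N+](=O)[O-])c1` differs from compound 3 by chloro in place of hydrogen on an aromatic carbon. For the measured compounds named here, no pair of tested compounds differs in this way, so there is no measured step to lean on; only a small shift, at most at the edge of the scatter and if anything towards a lower number, is expected. Compound 4 is therefore estimated at 110000 nM, within a range from 50000 nM to 200000 nM. This is expected as the step of a 1.4-fold lower number from compound 3 to compound 4 (0.13 log units; within the scatter).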

Compound 4, half-maximal inhibitory concentration: 170000 nM
The estimate for compound 4 lay 1.5-fold (0.19 log units) below the measured number, within the range that was stated.
By their numbers in this assay, from the lowest: compounds 3, 1 and 4 (each within the scatter of the next). At a limit, above all of these: compound 2.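

In this assay, chloro in place of hydrogen on the benzyl arm gives a 1.1-fold higher number from compound 3 to compound 4 (0.05 log units; within the scatter) and so leaves compounds 3 and 4 indistinguishable. For the compounds shown here, this is the first measured step at this position, on an aromatic carbon para to a large group, and it shows that benzyl and 4-chlorobenzyl cannot be told apart in this read-out. The information at hand offers no explanation that bears on this step.

From the compounds shown here alone, whether an amine, a carboxylic acid or a methoxy group at this position would also leave the number within the scatter stays open. So does the outcome of placing chloro elsewhere on this ring.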